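Amide-nitrogen substituent swap from compound 1 to compound 3

The source may hold more compounds than are shown below. What is called first, only, known or untested is meant among the compounds shown, and "the series" means these compounds.

Going by the values given here, compound 1 `CC(=O)Oc1ccc(N2C(=O)/C(=C/N3N=C(c4ccccc4)CC3c3ccccc3O)SC2=S)cc1` is the only member with a number in a functional assay on HL-60 cells (Homo sapiens) for antiproliferative activity, read by MTT assay, with a stated time of 72 h; a lower number here means a stronger inhibitor, a higher number a weaker inhibitor: compound 1 gives 9400 nM. Compound 2 `CCN1C(=O)/C(=C/N2N=C(c3ccccc3)CC2c2ccccc2O)SC1=S` reaches only a limit in this assay, and compound 2 is reported as > 10000 nM. Among the compounds with values here, the one measured step, an at least 1.0-fold higher number from compound 1 to compound 2 (0.02 log units; that floor lies within the scatter), is therefore set by the limit of > 10000 nM in this assay, at which 1 of the 2 values shown sits, and shows only that the number did not fall. Compound 3 `O=C1/C(=C/N2N=C(c3ccccc3)CC2c2ccccc2O)SC(=S)N1c1cccnc1` differs from compound 1 by pyridin-3-yl in place of 4-acetoxyphenyl on an amide-type nitrogen in a ring. An aromatic ring stays on the amide-type nitrogen in the ring, so the measured step, which puts ethyl in place of 4-acetoxyphenyl, bears only loosely on this change; it gives no sign of a gain, and a move toward the limit cannot be ruled out. The expected step in this assay is no change at the digits printed from compound 1 to compound 3 (within the scatter), within the scatter. Compound 3 is estimated at 9400 nM, with a range of 4000 nM to 22000 nM.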

Compound 3, half-maximal inhibitory concentration: 720 nM
Compound 3: middle estimate off by 13-fold (1.12 log units), on the high side; the measured number lies below the stated range.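

Pyridin-3-yl in place of 4-acetoxyphenyl gives a 13-fold lower number from compound 1 to compound 3 (1.12 log units; beyond the scatter) in this assay, so this amide-type nitrogen does respond to its substituent, and an aromatic ring there does not by itself set the number. Against ethyl, pyridin-3-yl gives an at least 13-fold lower number from compound 2 to compound 3 (1.14 log units; beyond the scatter). That second step is only a floor, because compound 2 stands at a limit and not at a number: the limit of > 10000 nM in this assay, at which 1 of the 3 values shown sits.

The step from 4-acetoxyphenyl to pyridin-3-yl removes the acetoxy group and brings in the ring nitrogen at once, and the compounds shown do not separate these two changes. Plain phenyl, 4-hydroxyphenyl or pyridin-4-yl on the same nitrogen would tell them apart and would show whether the placing of the ring nitrogen matters.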